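Benzyl variants of one core, all at the assay limit

This account rests on a few compounds, and the source may have more. Where it says the series, first, only, none or still open, it means among the compounds named here.

Three compounds share one core and differ only in the group carried on a saturated chain carbon bound to an aromatic nitrogen. Compound 1 `O=c1ccoc2cc(OCc3cn(Cc4ccc(Cl)cc4Cl)nn3)ccc12` carries 2,4-dichlorophenyl there; in a functional assay on MDA-MB-231 cells (Homo sapiens) for cytotoxicity, read by MTT assay, with a stated time of 48 h (on this read-out lower numbers stand for stronger inhibition and higher numbers for weaker inhibition), compound 1 gives > 100000 nM, which is a limit of the assay and not a number. Compound 2 `O=c1ccoc2cc(OCc3cn(Cc4ccc(F)cc4)nn3)ccc12` carries 4-fluorophenyl; in this assay compound 2 gives > 100000 nM, again a limit. Compound 3 `CC(C)(C)c1ccc(Cn2cc(COc3ccc4c(=O)ccoc4c3)nn2)cc1` carries tert-butyl in place of fluoro on the aromatic carbon; in this assay compound 3 gives > 100000 nM, also a limit. Compound 2 therefore stands at the limit, with both neighbouring values at the same place: the limit of > 100000 nM in this assay, at which 3 of the 3 values shown sit. The steps a step that the two limits leave unreadable from compound 1 to compound 2 and a step that the two limits leave unreadable from compound 2 to compound 3 are unreadable in size and direction.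

Compound 4 `O=c1ccoc2cc(OCc3cn(Cc4ccccc4Br)nn3)ccc12` differs from compound 2 by 2-bromophenyl in place of 4-fluorophenyl on a saturated chain carbon bound to an aromatic nitrogen, that is, 4-fluorobenzyl to 2-bromobenzyl. The two measured steps bear on it only in that each earlier change of this group left the value at the limit. Among the compounds with values here, no step of readable size exists, so no movement beyond the scatter is expected in this assay; the step that the limit leaves unreadable from compound 2 to compound 4 is expected to be negligible. Compound 4 is therefore estimated at 150000 nM, within 50000 nM to 500000 nM, most likely reported as a limit again.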

Compound 4, half-maximal inhibitory concentration: > 100000 nM
Compound 4: only a limit was reported; the forecaster's own chance of this, stated with the estimate: 85%; the middle value does not contradict the limit.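

In this assay compound 4 gives > 100000 nM, which is a limit of the assay and not a number. The steps from compound 1 and compound 2 to compound 4 therefore cannot be read. The compounds shown leave open whether any change of the group on the shared core gives a readable value: the limit of > 100000 nM in this assay, at which 4 of the 4 values shown sit.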